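The source may hold more compounds than are shown below. What is called first, only, known or untested is meant among the compounds shown, and "the series" means these compounds.

Compound 2 `O=C1c2ccccc2S(=O)(=O)N1CCCCCCN1CCN(c2cccc(Cl)c2Cl)CC1` gives 119 nM in an ADME assay on HEK293 cells for displacement of a labelled ligand from 5-hydroxytryptamine receptor 7 (Homo sapiens), read by radioligand binding, with a stated time of 1 h (on this read-out lower numbers stand for stronger inhibition and higher numbers for weaker inhibition), the lower of the two numbers shown, though compound 1 `O=C1c2ccccc2S(=O)(=O)N1CCCCCCN1CCN(c2cccc(Cl)c2)CC1` at 233 nM lies within the scatter of it. Going by the values given here, the only measured step, a 2.0-fold lower number from compound 1 to compound 2 (0.29 log units; within the scatter), is within the scatter. Compound 3 `O=C1c2ccccc2S(=O)(=O)N1CCCCCCN1CCN(c2ccc(Cl)c(Cl)c2)CC1` differs from compound 2 by 3,4-dichlorophenyl in place of 2,3-dichlorophenyl on an amine nitrogen in a ring. That step concerned adding a chlorine, not moving one, so it bears only loosely on this change. No step beyond the scatter is therefore expected, a 1.3-fold higher number from compound 2 to compound 3 (0.10 log units; within the scatter). Compound 3 is estimated at 150 nM, with a range from 50 nM to 450 nM.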

Compound 3, inhibition constant: 258 nM
Compound 3: the middle estimate sits 1.7-fold (0.24 log units) below what was measured; the measured number falls inside the stated range.
By their numbers in this assay, from the lowest: compounds 2, 1 and 3 (each within the scatter of the next, the first and the last beyond it).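

In this assay, 3,4-dichlorophenyl in place of 2,3-dichlorophenyl gives a 2.2-fold higher number from compound 2 to compound 3 (0.34 log units; beyond the scatter) with the same atoms on both sides, so the arrangement of the two chlorines on the phenyl ring has a modest bearing on the number. Chloro in place of hydrogen on an aromatic carbon gives a 1.1-fold higher number from compound 1 to compound 3 (0.04 log units; within the scatter) here, so this added chlorine does not set the two compounds apart. Nothing given here explains the difference between the two dichlorophenyl groups. From the compounds shown here alone, whether a methoxy or trifluoromethyl group in place of the chlorines, or a shorter chain to the shared core, would shift the number remains open.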